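Extending a Saturated Chain: Effect on Cell Growth Inhibition

The source may hold more compounds than are shown below. What is called first, only, known or untested is meant among the compounds shown, and "the series" means these compounds.

Compound 1, `CCCCCCC#Cc1cn(C/C=C/CN2C(=O)c3ccccc3C2=O)c(=O)[nH]c1=O`: in a functional assay on MCF7 cells (Homo sapiens) for antiproliferative activity, read by MTT assay, with a stated time of 3 days (on this read-out lower numbers stand for stronger inhibition and higher numbers for weaker inhibition), compound 1 gives 24000 nM.
Compound 2, `CCCCc1ccc(C#Cc2cn(C/C=C\CN3C(=O)c4ccccc4C3=O)c(=O)[nH]c2=O)cc1`: in this assay compound 2 gives 43000 nM.
Compound 3, `CCCCCc1ccc(C#Cc2cn(C/C=C\CN3C(=O)c4ccccc4C3=O)c(=O)[nH]c2=O)cc1`: in this assay compound 3 reaches only a limit of the assay, > 100000 nM.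

Of the two compounds with an actual number, compound 1 has the lower one, and its nearest neighbour is compound 2; the gap between them lies within the usual scatter of repeated measurements, so no order can be read between these two. Compound 3 stands apart at the limit of > 100000 nM in this assay, at which 1 of the 3 values shown sits.

Compound 4, `CCCCCCCCC#Cc1cn(C/C=C/CN2C(=O)c3ccccc3C2=O)c(=O)[nH]c1=O`, differs from compound 1 in one place: ethyl in place of hydrogen on a saturated chain carbon, six bonds along the chain from a triple-bonded carbon. Among the compounds with values here, no measured pair shows this exact change. Within the data shown here, the one measured step that resembles it, a growth of a saturated chain, is an at least 2.3-fold higher number from compound 2 to compound 3 (0.36 log units; beyond the scatter), and it moved toward weaker inhibition. That step concerns a chain attached through an aromatic ring and a different pair of compounds, so it bears on compound 4 only loosely. A modest weakening at most is therefore expected, possibly none beyond the scatter.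

Compound 4 is estimated to give 38000 nM in this assay, within a range of 12000 nM to 100000 nM. This expected outcome corresponds to a 1.6-fold higher number from compound 1 to compound 4 (0.20 log units; within the scatter).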

Compound 4, half-maximal inhibitory concentration: 66000 nM
The estimate for compound 4 lay 1.7-fold (0.24 log units) below the measured number; the range from low to high includes it.
By their numbers in this assay, from the lowest: compounds 1, 2 and 4 (each within the scatter of the next, the first and the last beyond it). At a limit, above all of these: compound 3.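

In this assay, adding ethyl on a saturated chain carbon, six bonds along the chain from a triple-bonded carbon, gives a 2.8-fold higher number from compound 1 to compound 4 (0.44 log units; beyond the scatter), so this place on the chain does respond to added saturated carbon, and the step goes beyond the scatter. The only chain growth known before belonged to a separate pair with an aromatic ring in the chain's attachment, an at least 2.3-fold higher number from compound 2 to compound 3 (0.36 log units; beyond the scatter), and the new step points the same way on a chain without that ring, so both chain extensions shown move toward weaker inhibition. Nothing measured here gives a reason for either step, and the cause stays unknown.

The compounds shown leave open whether a shorter chain in this place would give a lower number than compound 1, and whether the weakening continues with a still longer chain. They also leave open whether a chain ending in an amine or a carboxylic acid, instead of a plain saturated end, would stay close to compound 1 or move away from it.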